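The source may hold more compounds than are shown below. What is called first, only, known or untested is meant among the compounds shown, and "the series" means these compounds.

Measured compounds:
- compound 1 `C=CCn1c(=O)/c(=C\c2cccc(F)c2)[nH]c(=O)/c1=C\c1ccccc1OC`: 9100 nM
- compound 2 `C=CCn1c(=O)/c(=C\c2ccccc2C(F)(F)F)[nH]c(=O)/c1=C\c1ccccc1OC`: 4600 nM

Going by the values given here, in a functional assay on HeLa cells (Homo sapiens) for cytotoxicity, read by CCK-8 assay, with a stated time of 72 h (a lower number here means a stronger inhibitor, a higher number a weaker inhibitor), compound 2 gives 4600 nM, the lower of the two numbers so far; compound 1, the nearest, gives 9100 nM, and the only step in the set, a 2.0-fold lower number from compound 1 to compound 2 (0.30 log units; within the scatter), stays within the scatter. Compound 3 `C=CCn1c(=O)/c(=C\c2ccc(C)cc2)[nH]c(=O)/c1=C\c1ccccc1OC` has not yet been measured. It differs from compound 2 in one place: 4-methylphenyl in place of 2-(trifluoromethyl)phenyl on a double-bonded chain carbon bound to an aromatic carbon. Among the compounds with values here, the single measured step that bears on this change is the aryl exchange at the same place, which gave a 2.0-fold lower number from compound 1 to compound 2 (0.30 log units; within the scatter) and thus no movement beyond the scatter. With no other comparison available, compound 3 is expected to show a step of about a 1.3-fold higher number from compound 2 to compound 3 (0.12 log units; within the scatter) in this assay, that is, no change beyond the scatter. The estimate for compound 3 in this assay is 6000 nM, with a range from 2500 nM to 15000 nM.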

Compound 3, half-maximal inhibitory concentration: "not active" (no number reported)
Compound 3 has no reported number here, and the estimate cannot be compared.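

In this assay, going by these compounds alone, compound 3 is reported as "not active" without a number, so no step from compound 2 to compound 3 can be read. Nothing shown offers an explanation for this result. The compounds shown leave open how far 4-methylphenyl in place of 2-(trifluoromethyl)phenyl shifts the number.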